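Adding a Methyl Group to a Hydroxyl on a Bicyclic Lactone

The source may report more compounds than this note shows. Statements on the series, on what has been measured and on what is new or still open speak of the compounds shown alone.

Of the compounds shown here, three sharing one core have been measured in a functional assay on HeLa cells (Homo sapiens) for inhibition, read by MTT assay, with a stated time of 72 h; a lower number here means a stronger inhibitor, a higher number a weaker inhibitor. Compound 1 `O=C1C[C@H]2O[C@H]([C@H](O)c3ccccc3)[C@H](O)[C@H]2O1` gives 8320 nM. Compound 2 `CO[C@@H](c1ccccc1)[C@H]1O[C@@H]2CC(=O)O[C@@H]2[C@H]1O` gives 8460 nM, and compound 3 `CO[C@H](c1ccccc1)[C@H]1O[C@@H]2CC(=O)O[C@@H]2[C@H]1O` gives 5640 nM. The difference between the cores of compound 1 and compound 2 is not broken down here. Compound 2 and compound 3 share every atom and bond, and the step of a 1.5-fold lower number from compound 2 to compound 3 (0.18 log units; within the scatter) comes with the fact that compounds 2 and 3 differ only in the configuration as drawn. From compound 1 to compound 3 the change is methyl in place of hydrogen on an oxygen on a saturated carbon, and the step is a 1.5-fold lower number from compound 1 to compound 3 (0.17 log units; within the scatter).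

Compound 4 `CO[C@@H]1[C@H]2OC(=O)C[C@H]2O[C@@H]1[C@@H](OC)c1ccccc1`, not yet measured, carries the same kind of change relative to compound 2: methyl in place of hydrogen on an oxygen on a saturated carbon. The surroundings differ, though: in compound 1 the oxygen sits on a saturated carbon whose other neighbour is a saturated chain carbon, whereas in compound 2 that carbon's other neighbour is a saturated ring carbon. For the measured compounds named here, since the one measured step of this kind stayed within the scatter, the expected step in this assay is a 1.3-fold lower number from compound 2 to compound 4 (0.11 log units; within the scatter), resting on the step from compound 1 to compound 3. Compound 4 is therefore estimated at 6500 nM, with a likely range from 2500 nM to 17000 nM.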

Compound 4, half-maximal inhibitory concentration: 89300 nM
Compound 4: the middle estimate sits 14-fold (1.14 log units) below what was measured, outside the stated range (above it).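

In this assay, the change from hydroxy to methoxy, on a saturated carbon whose other neighbour is a saturated ring carbon, brings an 11-fold higher number from compound 2 to compound 4 (1.02 log units; beyond the scatter). For the compounds shown here, this same change therefore does not carry over with the same size from one core to another, as the two steps set side by side show: the same change on two cores in this assay, a 1.5-fold lower number (0.17 log units; within the scatter) from compound 1 to compound 3 and an 11-fold higher number (1.02 log units; beyond the scatter) from compound 2 to compound 4, 16-fold (1.19 log units) apart, beyond the scatter of two such steps What this does not show is why the two steps part, and with only one step in each setting it gives no general rule for other compounds.

From the compounds shown here alone, it remains open whether the same change made on compound 3, which has the other configuration as drawn at the chain carbon, would give a step of similar size. Also open, going by these compounds, is how the number would move with an ethyl group on that oxygen, or with an amine in place of the hydroxy group.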